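Halogen back in place of methoxy on the shared core

This account rests on a few compounds, and the source may have more. Where it says the series, first, only, none or still open, it means among the compounds named here.

Compound 3 `COc1ccc2c(c1)/C(=C1/Nc3ccccc3/C1=N\O)C(=O)N2Cc1ccc(/C=C/C(=O)NO)cc1` gives 50 nM in a functional assay on NCI-H23 cells (Homo sapiens) for cytotoxicity, read by colorimetric assay (a higher number here means a weaker inhibitor, a lower number a stronger inhibitor), the highest number of the three measured; the nearest is compound 2 `Cc1ccc2c(c1)/C(=C1/Nc3ccccc3/C1=N\O)C(=O)N2Cc1ccc(/C=C/C(=O)NO)cc1` at 10 nM, and compound 1 `O=C(/C=C/c1ccc(CN2C(=O)/C(=C3\Nc4ccccc4\C3=N/O)c3cc(Cl)ccc32)cc1)NO` at 7 nM lies furthest from it. The move to compound 4 `O=C(/C=C/c1ccc(CN2C(=O)/C(=C3\Nc4ccccc4\C3=N/O)c3cc(Br)ccc32)cc1)NO` is bromo in place of methoxy on an aromatic carbon. Among the compounds with values here, two measured steps bear on it: a 7.1-fold higher number from compound 1 to compound 3 (0.85 log units; beyond the scatter) and a 5.0-fold higher number from compound 2 to compound 3 (0.70 log units; beyond the scatter). Within the data shown here, the reverse of the first is the closest model available, bromo being, like chloro, a halogen; no pair here compares chloro with bromo directly. The step to compound 4 is therefore expected to run downward, a 6.3-fold lower number from compound 3 to compound 4 (0.80 log units; beyond the scatter), back toward the level of compound 1. Compound 4 is estimated at 8 nM, with a range from 3 nM to 25 nM.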

Compound 4, half-maximal inhibitory concentration: 9 nM
Compound 4: the middle estimate sits 1.1-fold (0.05 log units) below what was measured; the range from low to high includes it.
By their numbers in this assay, from the lowest: compounds 1, 4 and 2 (each within the scatter of the next); then compound 3.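

In this assay bromo at this position removes the loss seen with methoxy (a 5.6-fold lower number from compound 3 to compound 4 (0.74 log units; beyond the scatter)), and compound 4 stays within the scatter of the chloro compound (a 1.3-fold higher number from compound 1 to compound 4 (0.11 log units; within the scatter)) and of the methyl compound (a 1.1-fold lower number from compound 2 to compound 4 (0.05 log units; within the scatter)). Among these four compounds, chloro, bromo and methyl are not separated, and only methoxy, in compound 3, stands apart. No measurement at hand accounts for this difference. The compounds shown leave open how fluoro, hydroxy, an amine or a carboxylic acid would read at this position. As far as these compounds go, whether a longer ether such as ethoxy would follow methoxy also stays open.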